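The source may hold more compounds than are shown below. What is called first, only, known or untested is meant among the compounds shown, and "the series" means these compounds.

Compound 1 `CC(=O)CC[C@]1(C(C)=O)C(=O)O[C@@H](OC(C)=O)[C@H]1C` gives 6000 nM in a functional assay on MCF7 cells (Homo sapiens) for cytotoxicity, read by MTT assay (a higher number here means a weaker inhibitor, a lower number a stronger inhibitor), and compound 3 `CC(=O)[C@@]1(C)C(=O)O[C@@H](OC(=O)c2ccccc2)[C@H]1C` gives 3000 nM in this assay. Compound 2 `CC(=O)O[C@@H]1OC(=O)[C@](O)(C(C)=O)[C@@H]1C` reaches only a limit in this assay, namely > 50000 nM. That places compound 2 at the limit of > 50000 nM in this assay, at which 1 of the 3 values shown sits. Among the compounds with values here, the one measured step that leads to it, an at least 8.3-fold higher number from compound 1 to compound 2 (0.92 log units; beyond the scatter), raised the number well beyond the scatter. Compound 4 `CC(=O)O[C@@H]1OC(=O)[C@@H](C(C)=O)[C@@H]1C` differs from compound 2 by hydrogen in place of hydroxy on a saturated ring carbon. Within the data shown here, no measured step removes a hydroxy, so the step from compound 1 to compound 2 only shows that this ring position changes the number strongly. Compound 4 is therefore expected near 30000 nM, between 8000 nM and 80000 nM, which would be an expected step of an at least 1.6-fold lower number from compound 2 to compound 4 (0.22 log units; that floor lies within the scatter) in this assay.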

Compound 4, half-maximal inhibitory concentration: > 50000 nM
Compound 4 was reported as a limit; the forecaster's own chance of this, stated with the estimate: 45%; middle value at least 1.6-fold (0.22 log units) from the limit.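

In this assay, compound 4, with hydrogen in place of hydroxy on this saturated ring carbon, gives > 50000 nM, which is a limit of the assay. The step between compound 2 and compound 4 cannot be read from two limits, so the hydroxy shows no measurable effect here. Hydrogen in place of 2-acetylethyl gives an at least 8.3-fold higher number from compound 1 to compound 4 (0.92 log units; beyond the scatter), and both replacements of that chain end at the same limit: the limit of > 50000 nM in this assay, at which 2 of the 4 values shown sit.

Going by these compounds, it remains open whether an amine or a carboxylic acid on this carbon would give a number inside the assay's range. On these data alone, how far compound 2 and compound 4 lie beyond the limit also stays unknown.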